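Chloro on the cinnamamide ring of the shared core

A few compounds are considered here, and "the series" means these few. Any claim that something is new, unique, unknown or untested is made for them only; others in the source may bear on it.

In a functional assay on CHO cells for inhibition of transient receptor potential cation channel subfamily V member 1 (Homo sapiens) (a higher number here means a weaker inhibitor, a lower number a stronger inhibitor), compound 1 `CN(C)CCC/C(=C\C(=O)Nc1ccc2c(c1)OCCO2)c1ccc(C(C)(C)C)cc1` gives 3900 nM. Compound 2 `C/C(=C\c1ccc(C(C)(C)C)cc1)C(=O)Nc1ccc2c(c1)OCCO2` gives 100 nM in this assay. Compound 3 `O=C(/C=C/c1ccccc1)Nc1ccc2c(c1)OCCO2` reaches only a limit of this assay, > 4000 nM, so no number stands for it. This is the limit of > 4000 nM in this assay, at which 1 of the 3 values shown sits. Compound 4 `O=C(/C=C/c1ccc(Cl)cc1)Nc1ccc2c(c1)OCCO2` differs from compound 3 by chloro in place of hydrogen on an aromatic carbon. Compound 2, which carries a tert-butyl group on that ring, gives 100 nM. Compound 3 reaches only a limit of this assay. For the measured compounds named here, no step between measured compounds is directly known here. The step of an at least 2.0-fold lower number from compound 3 to compound 4 (0.30 log units; that floor lies within the scatter) is expected to run toward stronger inhibition, beyond the scatter. Compound 4 is estimated at 2000 nM, between 600 nM and 8000 nM.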

Compound 4, half-maximal inhibitory concentration: 250 nM
Estimate against measurement, compound 4: 8.0-fold (0.90 log units) above; measured number below the stated range.
By their numbers in this assay, from the lowest: compound 2; then compound 4; then compound 1. At a limit, above all of these: compound 3.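

Phenyl to 4-chlorophenyl is a productive change at this position, giving an at least 16-fold lower number from compound 3 to compound 4 (1.20 log units; beyond the scatter). A single chlorine atom, without a tert-butyl group on that ring, is enough to bring compound 4 to 250 nM in this assay. Compound 3 stands at a limit, so the size of this step is only a floor: the limit of > 4000 nM in this assay, at which 1 of the 4 values shown sits.

From the compounds shown here alone, whether fluoro, bromo or methoxy at the same place would give a step of similar size remains open. Also open, going by these compounds, is what a second chloro on that ring would add.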